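Cytotoxicity notes on two methyl-to-fluoro swaps

A few compounds are considered here, and "the series" means these few. Any claim that something is new, unique, unknown or untested is made for them only; others in the source may bear on it.

Compound 1 `C/C(=C\c1cc(-c2ccc(C)cc2)co1)C(N)=O` and compound 2 `C/C(=C\c1cc(-c2ccc(F)cc2)co1)C(N)=O` share one core; compound 3 `C/C(=C\c1ccc(-c2ccc(C)cc2)o1)C(N)=O` and the still unmeasured compound 4 `C/C(=C\c1ccc(-c2ccc(F)cc2)o1)C(N)=O` share another. The difference between the two cores is not broken down here. In an ADME assay on NIH3T3 cells (Mus musculus) for cytotoxicity, read by CCK-8 assay, with a stated time of 24 h (on this read-out higher numbers stand for weaker inhibition and lower numbers for stronger inhibition), compound 1 returns only a limit of the assay, > 50000 nM. Compound 2 likewise sits at a limit in this assay, > 50000 nM. Compound 3 too gives only a limit in this assay, > 50000 nM. The change from compound 1 to compound 2 is fluoro in place of methyl on an aromatic carbon; the step it made, a step that the two limits leave unreadable from compound 1 to compound 2, cannot be sized because of the limit of > 50000 nM in this assay, at which 3 of the 3 values shown sit. The change from compound 3 to compound 4 is fluoro in place of methyl on an aromatic carbon, the same change at a place described in the same words, so no size for it can be read from the measured pair either. With the three measured compounds all at the limit, the expected step from compound 3 to compound 4 is a step that the limit leaves unreadable from compound 3 to compound 4, which rests on the limit of > 50000 nM in this assay, at which 3 of the 3 values shown sit, rather than on any readable trend. Compound 4 is accordingly estimated at 60000 nM in this assay, and the most probable outcome is that this measurement is again reported only as a limit.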

Compound 4, half-maximal inhibitory concentration: 960 nM
Estimate against measurement, compound 4: 63-fold (1.80 log units) above; the measured number lies below the stated range.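

In this assay, fluoro in place of methyl on an aromatic carbon gives an at least 52-fold lower number from compound 3 to compound 4 (1.71 log units; beyond the scatter), so on the core of compound 3 this change is large and lies beyond the scatter. On the core of compound 1, compound 2 gives > 50000 nM, which is a limit of the assay and not a number. The same change therefore does not carry over in any measurable way, yet no absence of an effect on that core is shown either, and the step from compound 1 to compound 2 cannot be read because both of its values are limits: the limit of > 50000 nM in this assay, at which 3 of the 4 values shown sit.

The compounds shown leave open whether the large step is specific to fluoro or would also appear with chloro, trifluoromethyl or an amine in the same place on the core of compound 3. They also leave open how far below the limit, if at all, any compound on the core of compound 1 would fall in this assay.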